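A few compounds are considered here, and "the series" means these few. Any claim that something is new, unique, unknown or untested is made for them only; others in the source may bear on it.

Compound 3 `CCNC(=O)Nc1c(C)c(C(OC(C)(C)C)C(=O)O)c(-c2ccc(C)c(C)c2)c(C)c1-c1ccc(C)c(C)c1` gives 15000 nM in an ADME assay on MT4 cells (Homo sapiens) for cytotoxicity, read by MTT assay, with a stated time of 4 days (a higher number here means that more compound is tolerated, a lower number that less compound is tolerated), the second highest of the three numbers shown, close to compound 1 `CC(=O)Nc1c(C)c(C(OC(C)(C)C)C(=O)O)c(-c2ccc(C)c(C)c2)c(C)c1-c1ccc(C)c(C)c1` with 19000 nM and well apart from compound 2 `Cc1ccc(-c2c(C)c(-c3ccc(C)c(C)c3)c(C(OC(C)(C)C)C(=O)O)c(C)c2NCc2ccccc2)cc1C` with 4000 nM. Compound 4 `Cc1ccc(-c2c(C)c(-c3ccc(C)c(C)c3)c(C(OC(C)(C)C)C(=O)O)c(C)c2NS(=O)(=O)c2ccccc2)cc1C` carries phenylsulfonyl in place of ethylcarbamoyl on a nitrogen on an aromatic ring. The two steps taken at this nitrogen bear on it: a 4.8-fold lower number from compound 1 to compound 2 (0.68 log units; beyond the scatter) and a 3.8-fold higher number from compound 2 to compound 3 (0.57 log units; beyond the scatter), whereas the change at the carbonyl carbon, a 1.3-fold lower number from compound 1 to compound 3 (0.10 log units; within the scatter), stayed within the scatter. The group entering in compound 4 brings one six-membered aromatic ring of carbon only, as benzyl does in compound 2 at 4000 nM, so a modest drop is expected, a 2.5-fold lower number from compound 3 to compound 4 (0.40 log units; beyond the scatter). Compound 4 is estimated at 6000 nM, with a range from 2500 nM to 15000 nM.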

Compound 4, half-maximal cytotoxic concentration: 11000 nM
Beside the measured number, compound 4's estimate is 1.8-fold (0.26 log units) below it; low and high end bracket the measured number.
By their numbers in this assay, from the lowest: compound 2; then compounds 4, 3 and 1 (each within the scatter of the next).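

At this nitrogen on an aromatic ring, a six-membered aromatic ring of carbon only does not by itself bring the low number of the benzyl compound, as phenylsulfonyl gives (a 2.8-fold higher number from compound 2 to compound 4 (0.44 log units; beyond the scatter)) in this assay. Against the other two groups the change stays small (a 1.4-fold lower number from compound 3 to compound 4 (0.13 log units; within the scatter); a 1.7-fold lower number from compound 1 to compound 4 (0.24 log units; within the scatter)), leaving benzyl as the only group of the four set apart. Nothing shown explains the gap between benzyl and phenylsulfonyl. Open, going by these compounds, is whether methylsulfonyl or the free amine on this nitrogen would stay with compound 1, compound 3 and compound 4 or fall towards compound 2.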